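The source may report more compounds than this note shows. Statements on the series, on what has been measured and on what is new or still open speak of the compounds shown alone.

Three measured compounds are in view here: compound 1, `COc1ccccc1N1CCN(CCCNc2cncnc2C(=O)N(C)C)CC1`, compound 2, `COc1ccccc1N1CCN(CCCOc2ccccc2C(=O)N(C)C)CC1`, and compound 3, `CN(C)C(=O)c1cccnc1NCCCN1CCN(c2ccccc2C#N)CC1`. In a functional assay for antagonist activity at Alpha-1A adrenergic receptor (Oryctolagus cuniculus) (on this read-out higher numbers stand for weaker binding and lower numbers for tighter binding), compound 1 gives 3.98 nM. In this assay compound 2 gives 3.98 nM. In this assay compound 3 gives 2 nM, which is the lowest of the three numbers, though its gap to compound 1 and its gap to compound 2 each lie within the usual scatter of repeated measurements, so no ranking of the three can be drawn from these figures alone.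

The unmeasured compound 4, `CN(C)C(=O)c1cccnc1NCCCN1CCN(c2ccccc2C(F)(F)F)CC1`, is compound 3 with a single change: trifluoromethyl in place of cyano on an aromatic carbon. Among the compounds with values here, no measured pair in this set differs by this same change, so there is no measured step to lean on; the expectation rests only on the fact that compound 3 gives 2 nM and on the change being one group exchanged for another on an aromatic carbon. The step from compound 3 to compound 4 is expected to be small, a 3.0-fold higher number from compound 3 to compound 4 (0.48 log units; beyond the scatter), most likely toward a somewhat higher number and quite possibly none beyond the scatter. On that basis compound 4 is estimated at 6 nM, with a range from 2 nM to 20 nM.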

Compound 4, dissociation constant: 12.6 nM
Estimate against measurement, compound 4: 2.1-fold (0.32 log units) below; the range from low to high includes it.
By their numbers in this assay, from the lowest: compounds 3, 1 and 2 (each within the scatter of the next); then compound 4.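

In this assay, within the data shown here, exchanging 2-cyanophenyl for 2-(trifluoromethyl)phenyl gives a 6.3-fold higher number from compound 3 to compound 4 (0.80 log units; beyond the scatter), the first step in this set between compounds that differ in only one place. It shows that the binding number responds to the group on this aromatic carbon, something compounds 1, 2 and 3 could not show, since they differ from one another in more than one place. The change also alters more than one counted feature, raising the number of heavy atoms and removing the hydrogen-bond acceptor of the cyano group, and no measured evidence here says which of these matters, or whether something else does.

Among these compounds, a single step gives only one comparison at this position, so it remains open how a chlorine atom, an amine or a carboxylic acid on the same aromatic carbon would compare with cyano and trifluoromethyl. From the compounds shown here alone, it is also open whether the same exchange would give a step of similar size on the core of compound 1 or compound 2, or with the trifluoromethyl group elsewhere on the ring.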